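Swapping 3-methoxyphenyl for 2-ethylphenyl on an oxygen

The compounds below may be only part of what the source reports. "The series", "measured", "known", "first", "only" and "open" are said of these compounds alone.

Measured compounds in a functional assay on MCF7 cells (Homo sapiens) for antiproliferative activity, read by MTT assay, with a stated time of 72 h; on this read-out lower numbers stand for stronger inhibition and higher numbers for weaker inhibition:
- Compound 1 `COc1cc(/C=C/c2ccc(C3=C(c4ccc(O)cc4)C4CC(S(=O)(=O)Oc5ccc(Br)cc5)C3O4)cc2)cc(OC)c1`: > 100000 nM, a limit of the assay
- Compound 2 `COc1cc(/C=C/c2ccc(C3=C(c4ccc(O)cc4)C4CC(S(=O)(=O)Oc5cccc(OC)c5)C3O4)cc2)cc(OC)c1`: 77100 nM

Going by the values given here, compound 2 holds the only actual number so far. Compound 1 sits at a limit: the limit of > 100000 nM in this assay, at which 1 of the 2 values shown sits.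

Compound 3 `CCc1ccccc1OS(=O)(=O)C1CC2OC1C(c1ccc(/C=C/c3cc(OC)cc(OC)c3)cc1)=C2c1ccc(O)cc1` keeps the core of compound 2 and changes one group: 2-ethylphenyl in place of 3-methoxyphenyl on an oxygen. Here 2-ethylphenyl replaces 3-methoxyphenyl on an oxygen whose other neighbour is the sulfonyl sulfur.

Among the compounds with values here, only one measured step bears on this change. It is an at least 1.2-fold lower number from compound 1 to compound 2 (0.11 log units; that floor lies within the scatter), which lies within the scatter and involves the same place. No clear shift in this assay is therefore expected, in either direction, and a result at the limit remains possible. The expected 1.1-fold lower number from compound 2 to compound 3 (0.04 log units; within the scatter) stays within the scatter. For compound 3 the estimate is 70000 nM, with an expected range from 35000 nM to 100000 nM.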

Compound 3, half-maximal inhibitory concentration: 49800 nM
For compound 3 the middle estimate is 1.4-fold (0.15 log units) above the measured one, and the stated range covers the measured number.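

The new result gives this position a second actual number: in this assay, putting 2-ethylphenyl in place of 3-methoxyphenyl gives a 1.5-fold lower number from compound 2 to compound 3 (0.19 log units; within the scatter). The group on the oxygen can therefore change from one with a hydrogen-bond acceptor to one made only of carbon and hydrogen with no clear shift in the read-out, something compound 1 could not show. The comparison with the 4-bromophenyl group shows an at least 2.0-fold lower number from compound 1 to compound 3 (0.30 log units; that floor lies within the scatter), and this is only a floor, as compound 1 remains a limit: the limit of > 100000 nM in this assay, at which 1 of the 3 values shown sits.

From the compounds shown here alone, it remains open whether a group of another kind on this oxygen, such as a phenyl ring carrying an amine or a carboxylic acid, or one with a longer chain in place of ethyl, would move the number beyond the scatter. The step from compound 2 to compound 3 also changes the substituent and its place on the ring together, so the two cannot be told apart.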